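Urea substitution and intestinal acyl-CoA:cholesterol acyltransferase inhibition

The compounds below may be only part of what the source reports. "The series", "measured", "known", "first", "only" and "open" are said of these compounds alone.

Measured compounds:
compound 1, `CC(C)c1cccc(C(C)C)c1NC(=O)NCC1(c2cccc3ccccc23)CCCC1`, 34 nM
compound 2, `Cc1cccc(NC(=O)NCC2(c3ccccc3)CCCCC2)c1`, 2800 nM

In an assay on microsomes from intestine for inhibition of acyl-CoA:cholesterol acyltransferase (Oryctolagus cuniculus) (a lower number here means a stronger inhibitor, a higher number a weaker inhibitor), compound 1 gives 34 nM. In this assay compound 2 gives 2800 nM, the highest number of the two, and the gap to compound 1 lies beyond the scatter of repeated measurements, so compound 2 is the weaker inhibitor of the pair.

Compound 3, `O=C(NCC1(c2ccccc2)CCCCC1)Nc1cc(Cl)ccc1Cl`, is the next compound considered. Relative to compound 2 the change is 2,5-dichlorophenyl in place of 3-methylphenyl on an amide-type nitrogen, so the aryl group on the urea is exchanged while the rest of the molecule is kept. Going by the values given here, no measured pair here isolates this exchange, and the only comparison available is the gap between compound 2 and compound 1, whose structures differ in more than one place.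

The expected step from compound 2 to compound 3 in this assay is a 4.0-fold lower number from compound 2 to compound 3 (0.60 log units; beyond the scatter), a modest move toward a lower number, uncertain in size. For compound 3 the estimate in this assay is 700 nM, with a range from 200 nM to 2500 nM.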

Compound 3, half-maximal inhibitory concentration: 2700 nM
Beside the measured number, compound 3's estimate is 3.9-fold (0.59 log units) below it, outside the stated range (above it).
By their numbers in this assay, from the lowest: compound 1; then compounds 3 and 2 (each within the scatter of the next).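

In this assay, putting 2,5-dichlorophenyl in place of 3-methylphenyl on the amide-type nitrogen gives a 1.0-fold lower number from compound 2 to compound 3 (0.02 log units; within the scatter), and this step lies within the scatter. Going by these compounds alone, it is the first step available that changes only one place, and it shows that this exchange of aryl groups on the urea, with the rest of the molecule kept, produces no measurable difference in this read-out. No supporting information bears on why the two aryl groups cannot be told apart here, so the result stands as an observation only.

As far as these compounds go, the two aryl groups compared here both carry only small substituents, so it remains open whether an aryl group bearing an amine or a carboxylic acid at this place would leave the number equally unchanged. Compound 1, at 34 nM, differs from the other two compounds in more than one place, so the compounds shown do not tell which of its structural differences accounts for its value, or whether the aryl group on the urea contributes to it at all.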